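The source may report more compounds than this note shows. Statements on the series, on what has been measured and on what is new or still open speak of the compounds shown alone.

Compound 1, whose structure is `CC(C)(C)NCc1cc(Cl)cc(Nc2nc3ccccc3n2Cc2ccc(C(F)(F)F)cc2)c1O`, is tested in an ADME assay on CHO cells (Cricetulus griseus) for inhibition, read by MTT assay (a lower number here means a stronger inhibitor, a higher number a weaker inhibitor), and gives 36300 nM. Compound 2, with the structure `CCN(CC)Cc1cc(Cl)cc(Nc2nc3ccccc3n2Cc2ccc(C(F)(F)F)cc2)c1O`, differs from it by diethylamino in place of (tert-butyl)amino on a saturated chain carbon bound to an aromatic carbon. In this assay compound 2 reaches only the limit of > 50000 nM, which marks a boundary of the measurement and not a number. The step between them is an at least 1.3-fold higher number from compound 1 to compound 2 (0.13 log units; that floor lies within the scatter), and it rests on (the limit of > 50000 nM in this assay, at which 1 of the 3 values shown sits).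

Compound 3 has the structure `Cc1cc(CNC(C)(C)C)c(O)c(Nc2nc3ccccc3[nH]2)c1` and gives 33300 nM in this assay. How its core differs from the core of compound 1 is not broken down here. Compound 4, structure `CCN(CC)Cc1cc(C)cc(Nc2nc3ccccc3[nH]2)c1O`, is not yet measured; it differs from compound 3 by diethylamino in place of (tert-butyl)amino on a saturated chain carbon bound to an aromatic carbon, the same change as that from compound 1 to compound 2, at the same kind of place.

For compound 4 the expected step is a 1.7-fold higher number from compound 3 to compound 4 (0.22 log units; within the scatter), which is estimated to resemble the step from compound 1 to compound 2 in direction, since that step read an at least 1.3-fold higher number from compound 1 to compound 2 (0.13 log units; that floor lies within the scatter). Compound 4 is therefore expected to give about 55000 nM, somewhere between 30000 nM and 100000 nM.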

Compound 4, half-maximal inhibitory concentration: > 50000 nM
Compound 4: a limit, no number; the forecaster's own chance of this, stated with the estimate: 55%; the middle value is on the limit's open side.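

In this assay compound 4 reaches only a limit, > 50000 nM, which is a boundary of the measurement and not a number. Putting diethylamino in place of (tert-butyl)amino on this second core gives an at least 1.5-fold higher number from compound 3 to compound 4 (0.17 log units; that floor lies within the scatter), so what was seen on the first core is not contradicted here, and the two can be set side by side: the same change on two cores in this assay, an at least 1.3-fold higher number (0.13 log units; that floor lies within the scatter) from compound 1 to compound 2 and an at least 1.5-fold higher number (0.17 log units; that floor lies within the scatter) from compound 3 to compound 4; the limit leaves it open whether they differ. This does not show that the change truly weakens inhibition on either core, or that it does so by the same amount on both, because neither step has a real size and each ends at a limit: the limit of > 50000 nM in this assay, at which 2 of the 4 values shown sit.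

The compounds shown leave open how far past that limit compound 2 and compound 4 really lie. They also leave open how other amines on the same saturated chain carbon, such as dimethylamino, piperidine or morpholine, would read on these two cores.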